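The source may report more compounds than this note shows. Statements on the series, on what has been measured and on what is new or still open speak of the compounds shown alone.

In a functional assay on KB cells (Homo sapiens) for inhibition (a higher number here means a weaker inhibitor, a lower number a stronger inhibitor), compound 1 `CCOC[C@H]1O[C@@H](n2c(Cl)nc3cc(Cl)c(Cl)cc32)[C@H](OC(C)=O)[C@@H]1OC(C)=O` gives 60000 nM and compound 2 `CC(=O)OC1C(CCl)OC(n2c(Cl)nc3cc(Cl)c(Cl)cc32)C1OC(C)=O` gives 90000 nM. These two numbers lie within the usual scatter of each other, and compound 2 holds the higher one. Compound 3 `CSCC1OC(n2c(Cl)nc3cc(Cl)c(Cl)cc32)C(OC(C)=O)C1OC(C)=O` has not yet been measured. It differs from compound 2 by methylsulfanyl in place of chloro on a saturated chain carbon bound to a saturated ring carbon, with methylsulfanyl in place of chloro on a saturated chain carbon bound to a saturated ring carbon. For the measured compounds named here, no measured pair shows this change, and no step beyond the scatter is expected. The estimated step, a 1.3-fold lower number from compound 2 to compound 3 (0.11 log units; within the scatter), stays within that scatter. For compound 3 the estimated value is 70000 nM, with an expected range from 25000 nM to 170000 nM.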

Compound 3, half-maximal inhibitory concentration: 70000 nM
Compound 3: the middle estimate sits on the measured number at the digits printed; the range from low to high includes it.
By their numbers in this assay, from the lowest: compounds 1, 3 and 2 (each within the scatter of the next).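

In this assay, for the compounds shown here, putting methylsulfanyl in place of chloro on a saturated chain carbon bound to a saturated ring carbon gives a 1.3-fold lower number from compound 2 to compound 3 (0.11 log units; within the scatter) and is the first single-place comparison at this position. Going by these compounds alone, exchanging one heavy atom for two here therefore produces no step that stands out from the scatter. No measurement at hand offers an explanation for this result. Still open, going by these compounds, is whether an amine or a carboxylic acid at this position would shift the number beyond the scatter. On these data alone, a longer chain on the sulfur remains equally open.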